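Extending the amide aryl group of compound 2

The compounds below may be only part of what the source reports. "The series", "measured", "known", "first", "only" and "open" are said of these compounds alone.

For the measured compounds named here, compound 2 `NCCCNCCCCNCCCNC(=O)[C@H](CC1CCCCC1)NC(=O)c1ccccc1` gives 21.4 nM in an assay on cells for antagonist activity at Neuronal acetylcholine receptor; alpha4/beta2 (Homo sapiens), read by two-electrode voltage clamp, with a stated time of 1 min (on this read-out lower numbers stand for stronger inhibition and higher numbers for weaker inhibition), the higher of the two numbers so far, while compound 1 `NCCCNCCCCNCCCNC(=O)[C@H](CC1CCCCC1)NC(=O)C1CCCC1` gives 5.43 nM. Going by the values given here, the one measured step, a 3.9-fold higher number from compound 1 to compound 2 (0.60 log units; beyond the scatter), exchanged a saturated ring for an aromatic one on the carbonyl carbon. Compound 3 `NCCCNCCCCNCCCNC(=O)[C@H](CC1CCCCC1)NC(=O)c1ccc(-c2ccccc2)cc1` carries phenyl in place of hydrogen on an aromatic carbon, para to a large group, which read one bond further out is phenyl to 4-phenylphenyl. Among the compounds with values here, no measured step enlarges an aromatic ring, so a 3.9-fold higher number from compound 1 to compound 2 (0.60 log units; beyond the scatter) bears only loosely. A step toward a higher number is expected here, a 1.6-fold higher number from compound 2 to compound 3 (0.21 log units; within the scatter). Compound 3 is estimated at 35 nM, within 9 nM to 140 nM.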

Compound 3, half-maximal inhibitory concentration: 25.8 nM
Compound 3: the middle estimate sits 1.4-fold (0.13 log units) above what was measured; the range from low to high includes it.
By their numbers in this assay, from the lowest: compound 1; then compounds 2 and 3 (each within the scatter of the next).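

Phenyl on an aromatic carbon, para to a large group, is tolerated in this assay (a 1.2-fold higher number from compound 2 to compound 3 (0.08 log units; within the scatter)), so this position accepts a second six-membered aromatic ring without a change outside the scatter. The extension does not close the gap to the cyclopentyl amide of compound 1 (a 4.8-fold higher number from compound 1 to compound 3 (0.68 log units; beyond the scatter)). No evidence is at hand that explains this result. Still open, going by these compounds, is how a methoxy group, an amine or a carboxylic acid at this position would read. On these data alone, a longer chain in place of the phenyl also remains open.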